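Dimethoxyphenyl in place of dichlorophenyl on the carbonyl carbon

The source may hold more compounds than are shown below. What is called first, only, known or untested is meant among the compounds shown, and "the series" means these compounds.

Compound 1, `COc1ccc(-c2cc(/C=C/C(=O)c3ccc(OC)c(OC)c3)[nH]n2)cc1`, gives 98% in a functional assay on MDA-MB-231 cells (Homo sapiens) for cytotoxicity, read by sulforhodamine B assay, with a stated time of 48 h, tested at 0.01 uM; a higher number here means a weaker effect of the compound at the concentration tested, a lower number a stronger effect.
Compound 2, `COc1cc(-c2cc(/C=C/C(=O)c3ccc(Cl)c(Cl)c3)[nH]n2)cc(OC)c1OC`, gives 103% in this assay.
Compound 3, `COc1ccc(-c2cc(/C=C/C(=O)c3ccc(N)cc3)[nH]n2)cc1OC`, gives 113% in this assay.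

Compound 2 stands second highest of the three numbers in this assay; its nearest neighbour is compound 1 and its furthest is compound 3, and both of those gaps lie within the scatter, so the three compounds cannot be told apart. Compound 4, `COc1ccc(C(=O)/C=C/c2cc(-c3cc(OC)c(OC)c(OC)c3)n[nH]2)cc1OC`, differs from compound 2 in one place: 3,4-dimethoxyphenyl in place of 3,4-dichlorophenyl on a carbonyl carbon. For the measured compounds named here, no measured pair shows this change, so the size of the step must be expected rather than read. A step no larger than the scatter is expected in either direction, because compound 1 gives 98% with 3,4-dimethoxyphenyl on its carbonyl carbon. Compound 4 is therefore estimated at 100%, within 88% to 112%. The expected step is a number 3 percentage points lower from compound 2 to compound 4 (within the scatter).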

Compound 4, a percentage reported as activity, at one concentration (the size of the read-out at that concentration, not a potency): 104%
Compound 4: the middle estimate sits 4 percentage points below what was measured; measured number inside the range.
By their numbers in this assay, from the lowest: compounds 1, 2, 4 and 3 (each within the scatter of the next, the first and the last beyond it).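

For the compounds shown here, the first direct reading of this change comes from the pair that differs only on the carbonyl carbon. In this assay, 3,4-dimethoxyphenyl in place of 3,4-dichlorophenyl gives a number 1 percentage points higher from compound 2 to compound 4 (within the scatter), so at this concentration the two groups cannot be told apart on this core. No evidence here bears on why the step is this small. The compounds shown leave open whether a carboxylic acid on that carbonyl carbon's phenyl ring, or a pyridine in place of that ring, would give a step beyond the scatter.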